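The source may report more compounds than this note shows. Statements on the series, on what has been measured and on what is new or still open speak of the compounds shown alone.

Measured compounds:
Compound 1 `C=CCOc1cc(C2=C(c3cc(OC)c(OC)c(OC)c3)C(=O)C(O)C2)ccc1OC` gives > 100 ug/mL.
Compound 2 `COc1ccc(C2=C(c3cc(OC)c(OC)c(OC)c3)C(=O)CC2O)cc1O` gives > 100 ug/mL.
Compound 3 `COc1cc(C2=C(c3ccccc3)C(O[SiH2]C(C)(C)C)CC2=O)cc(OC)c1OC` gives > 100 ug/mL.

In an ADME assay on MIA PaCa-2 cells (Homo sapiens) for cytotoxicity, read by MTT assay, with a stated time of 72 h (a higher number here means a weaker inhibitor, a lower number a stronger inhibitor), compound 1 reaches only > 100 ug/mL, which is a limit of the assay and not a number. Compound 2 likewise sits at > 100 ug/mL, a limit. Compound 3 also sits at > 100 ug/mL, a limit. Across the set there is the limit of > 100 ug/mL in this assay, at which 3 of the 3 values shown sit, so compound 1 stands where every other measured compound stands, and no real difference among them can be told.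

Compound 4 `COc1ccc(C2=C(c3cc(OC)c(OC)c(OC)c3)C(=O)C(O)C2)cc1OC(C)C` differs from compound 1 by isopropyl in place of allyl on an oxygen on an aromatic ring. For the measured compounds named here, with no measured step between compounds to draw on, a step of no size beyond the scatter is expected in this assay. Compound 4 is therefore expected to give 150 ug/mL, between 60 ug/mL and 400 ug/mL, an expected step that the limit leaves unreadable from compound 1 to compound 4.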

Compound 4, half-maximal inhibitory concentration: > 100 ug/mL
Compound 4 was reported as a limit; the forecaster's own chance of this, stated with the estimate: 80%; the middle value is on the limit's open side.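

No step can be read from compound 1 to compound 4, because both results are limits of the assay and not numbers: the limit of > 100 ug/mL in this assay, at which 4 of the 4 values shown sit.

The compounds shown leave open what would give a value other than a limit in this assay.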